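The source may report more compounds than this note shows. Statements on the series, on what has been measured and on what is new or still open speak of the compounds shown alone.

Series notes, step from compound 1 to compound 4.

In an ADME assay for permeability, using PAMPA, with a stated time of 30 min, at pH 7.4 (a lower number here means that the compound crosses the layer more slowly, a higher number that the compound crosses the layer faster), compound 1 `CCC(CC)c1ccc2c(NCCCNCc3cccc(OC)c3O)ccnc2c1` gives 23 10^-6 cm/s. Compound 2 `Cc1cc(C)cc(Cc2ccc3c(NCCCNCc4ccco4)ccnc3c2)c1` gives 23 10^-6 cm/s in this assay, so the two stand level at the digits recorded, within the scatter, and together they form the low end of the three numbers in hand. Compound 3 `c1coc(CNCCCNc2ccnc3cc(-c4cccc5ccccc45)ccc23)c1` gives 237 10^-6 cm/s in this assay, the furthest from compound 1 and beyond the scatter. Among the measured compounds shown here, the only single-site step among the measured compounds is a 10-fold higher number from compound 2 to compound 3 (1.01 log units; beyond the scatter), where naphthalen-1-yl replaced 3,5-dimethylbenzyl on an aromatic carbon of the core.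

Compound 4 `COc1cccc(CNCCCNc2ccnc3cc(Oc4ccc(C(C)(C)C)cc4)ccc23)c1O` is not yet measured. It differs from compound 1 by 4-(tert-butyl)phenoxy in place of pentan-3-yl on an aromatic carbon. For the measured compounds named here, the step from compound 2 to compound 3 is the only guide: an aromatic group entering on the core in place of a non-aromatic one went with a large rise. The change into compound 4 also brings an aromatic ring onto the core in place of a chain, but with an oxygen link and a tert-butyl, so the guide is loose. The expected step, a rise beyond the scatter yet smaller than the measured one, is estimated as a 2.6-fold higher number from compound 1 to compound 4 (0.42 log units; beyond the scatter). Compound 4 is therefore estimated at 60 10^-6 cm/s in this assay, between 20 10^-6 cm/s and 200 10^-6 cm/s.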

Compound 4, apparent permeability: 317 10^-6 cm/s
For compound 4 the middle estimate is 5.3-fold (0.72 log units) below the measured one; the measured number lies above the stated range.
By their numbers in this assay, from the lowest: compounds 1 and 2 (each within the scatter of the next); then compounds 3 and 4 (each within the scatter of the next).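

At this aromatic carbon of the shared core, in this assay, 4-(tert-butyl)phenoxy in place of pentan-3-yl goes with a 14-fold higher number from compound 1 to compound 4 (1.14 log units; beyond the scatter), so a large rise is now seen on the side-chain background of compound 1 as well as on that of compound 2. The earlier step, a 10-fold higher number from compound 2 to compound 3 (1.01 log units; beyond the scatter), exchanged one ring-bearing group for another, whereas here a group with no ring leaves and one with a six-membered aromatic ring and an oxygen link enters, so a large step at this position does not depend on a ring being present in the group that leaves. No measurement in hand bears on why the number rises at this position.

The oxygen link, the aromatic ring and the tert-butyl enter together, so the compounds shown leave open which of these parts carries the step, and plain phenoxy or a directly attached 4-(tert-butyl)phenyl would separate them. Also open, on these data alone, is how this position responds to a saturated ring such as cyclohexyl, or to a group of a different kind such as morpholine or a carboxylic acid.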